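Moving the Fluorine on the Phenylpiperazine Ring

The compounds below may be only part of what the source reports. "The series", "measured", "known", "first", "only" and "open" are said of these compounds alone.

Compound 2 `O[C@@H](COc1ccc(C(F)(F)F)cc1)CN1CCN(c2ccc(F)cc2)CC1` gives 53.7% in an assay on HEK293 cells for inhibition of Voltage-dependent T-type calcium channel subunit alpha-1G (Homo sapiens), read by patch clamp, tested at 10 uM (a lower number here means less inhibition, a higher number more inhibition at the concentration tested (going by the name of the read-out)), the highest of the three numbers measured. Compound 1 `O[C@@H](COc1ccc(F)cc1)CN1CCN(c2ccc(F)cc2)CC1` gives 47.5%, and compound 3 `O[C@@H](COc1ccc(Cl)cc1)CN1CCN(c2ccc(F)cc2)CC1` gives 39.7%. The steps of a number 6.2 percentage points higher from compound 1 to compound 2 (within the scatter) and a number 7.8 percentage points lower from compound 1 to compound 3 (within the scatter) lie within the scatter, whereas a number 14 percentage points lower from compound 2 to compound 3 (beyond the scatter) is a modest step beyond it. Compound 4 `O[C@@H](COc1ccc(C(F)(F)F)cc1)CN1CCN(c2ccccc2F)CC1` differs from compound 2 by 2-fluorophenyl in place of 4-fluorophenyl on an amine nitrogen in a ring. Among the measured compounds shown here, none of the measured steps bears on this change: all three concern groups on the aryl ether, not on the amine nitrogen in a ring. With nothing measured to guide it, the expected step for compound 4 is a number 1.7 percentage points lower from compound 2 to compound 4 (within the scatter), nothing beyond the scatter. Compound 4 is therefore estimated at 52%, within 35% to 70%.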

Compound 4, a percentage reported as inhibition, at one concentration (the size of the read-out at that concentration, not a potency): 50.2%
Compound 4: middle estimate off by 1.8 percentage points, on the high side, within the range that was stated.
By their numbers in this assay, from the lowest: compounds 3, 1, 4 and 2 (each within the scatter of the next, the first and the last beyond it).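

In this assay, 2-fluorophenyl in place of 4-fluorophenyl on the amine nitrogen in a ring gives a number 3.5 percentage points lower from compound 2 to compound 4 (within the scatter) and is the only step shown at this place, the other steps all concerning the aryl ether. With trifluoromethyl on the aryl ether, the two fluorophenyl groups cannot be told apart in this read-out. Nothing measured here offers an explanation for this result.

On these data alone, whether a plain phenyl or a methoxyphenyl group on that nitrogen would move the number remains open. So does whether the same change behaves alike with fluoro or chloro on the aryl ether.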